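Piperidin-1-yl in Place of Piperazin-1-yl

The source may report more compounds than this note shows. Statements on the series, on what has been measured and on what is new or still open speak of the compounds shown alone.

In a functional assay on MDA-MB-231 cells (Homo sapiens) for cytotoxicity, read by MTT assay, with a stated time of 72 h (a lower number here means a stronger inhibitor, a higher number a weaker inhibitor), compound 1 `O=C1c2c[n+]([O-])c3ccccc3c2C(=O)c2c1c1ccccc1n2Cc1cn(C[C@H](O)CO)nn1` gives 1310 nM as its reading. Compound 2 `O=C1c2c[n+]([O-])c3ccccc3c2C(=O)c2c1c1ccccc1n2Cc1cn(CC(O)CO)nn1` gives 1290 nM as its reading. These two differ only in the fact that one of compounds 1 and 2 is drawn with a defined configuration and the other without, at the place where they differ and the step is a 1.0-fold lower number from compound 1 to compound 2 (0.01 log units; within the scatter) with no further change in structure. Compound 3 `O=C1c2c[n+]([O-])c3ccccc3c2C(=O)c2c1c1ccccc1n2CCCCN1CCNCC1` stands at 3310 nM in this assay and has the highest number of the three, so it is the weakest so far. Replacing the 1-(2,3-dihydroxypropyl)-1H-1,2,3-triazol-4-yl group with 3-(piperazin-1-yl)propyl gives a 2.5-fold higher number from compound 1 to compound 3 (0.40 log units; beyond the scatter) and also a 2.6-fold higher number from compound 2 to compound 3 (0.41 log units; beyond the scatter) as modest steps.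

Compound 4 `O=C1c2c[n+]([O-])c3ccccc3c2C(=O)c2c1c1ccccc1n2CCCCN1CCCCC1` changes compound 3 only at the ring: piperidin-1-yl in place of piperazin-1-yl on a saturated chain carbon, four bonds along the chain from an aromatic nitrogen with piperidin-1-yl entering on a saturated chain carbon, four bonds along the chain from an aromatic nitrogen. Within the data shown here, no measured step covers this exchange directly, and the two modest steps above are the nearest guide, for a far larger change of group. The estimated step of a 1.3-fold lower number from compound 3 to compound 4 (0.12 log units; within the scatter) is therefore expected to stay within the scatter, slightly towards a lower number. For compound 4 the expected value is 2500 nM in this assay with an estimated range from 1000 nM to 6000 nM as its limits.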

Compound 4, half-maximal inhibitory concentration: 610 nM
For compound 4 the middle estimate is 4.1-fold (0.61 log units) above the measured one; the whole stated range lies above it.
By their numbers in this assay, from the lowest: compound 4; then compounds 2 and 1 (each within the scatter of the next); then compound 3.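

In this assay, the ring at the end of the chain matters: on a saturated chain carbon, four bonds along the chain from an aromatic nitrogen, piperidin-1-yl in place of piperazin-1-yl gives a 5.4-fold lower number from compound 3 to compound 4 (0.73 log units; beyond the scatter), although both groups have the same count of heavy atoms and differ by one ring nitrogen and one hydrogen-bond donor. The side chain with this ring also changes its standing against the triazole compounds, which compound 3 had trailed, with a 2.1-fold lower number from compound 2 to compound 4 (0.33 log units; beyond the scatter) and a 2.1-fold lower number from compound 1 to compound 4 (0.33 log units; beyond the scatter). Nothing available explains the size of this step.

The compounds shown leave open whether a morpholine or 4-methylpiperazine ring at the same place would read closer to compound 3 or to compound 4. They also leave open whether the piperidine result holds with an ethyl or butyl linker in place of the propyl one.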